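Homodimeric hydroxamate chain extension in a coumarin-derived series

The source may report more compounds than this note shows. Statements on the series, on what has been measured and on what is new or still open speak of the compounds shown alone.

Compound 1 `CC(C)CCc1c(OCCCCCC(=O)NO)ccc2ccc(=O)oc12` and compound 2 `CC(C)CCc1c(OCCCCC(=O)NO)ccc2ccc(=O)oc12` share one core and differ only in the length of the chain carrying the hydroxamic acid. In a functional assay on A549 cells (Homo sapiens) for antiproliferative activity, read by sulforhodamine B assay, with a stated time of 48 h (a lower number here means a stronger inhibitor of growth, a higher number a weaker inhibitor of growth), compound 1 gives 870 nM, and compound 2 gives 2760 nM. The change between them is (hydroxycarbamoyl)methyl in place of hydroxycarbamoyl on a saturated chain carbon, four bonds along the chain from an oxygen on an aromatic ring, and it made a step of a 3.2-fold lower number from compound 2 to compound 1 (0.50 log units; beyond the scatter).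

Compound 3 `CC(C)CCc1c(OCCCCC(=O)NO)ccc(CCC(=O)NO)c1O` rests on a different core, which carries a second hydroxamic acid on its own chain; how its core differs from that of compound 2 is not broken down here. In this assay compound 3 gives 10000 nM, the highest number among the three measured compounds.

Compound 4 `CC(C)CCc1c(OCCCCCC(=O)NO)ccc(CCC(=O)NO)c1O` is not yet measured. It differs from compound 3 by (hydroxycarbamoyl)methyl in place of hydroxycarbamoyl on a saturated chain carbon, four bonds along the chain from an oxygen on an aromatic ring, the same change that took compound 2 to compound 1, at a place described in the same words. Going by the values given here, the expectation for compound 4 rests on that single earlier step alone: a second core and the extra chain are present, and no measured pair on that core shows how the change behaves there. With that reservation, the step from compound 3 to compound 4 in this assay is estimated at a 2.9-fold lower number from compound 3 to compound 4 (0.46 log units; beyond the scatter). Compound 4 is therefore expected to give about 3500 nM in this assay, with a plausible range from 1200 nM to 10000 nM.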

Compound 4, concentration for 50% growth inhibition: 5410 nM
Estimate against measurement, compound 4: 1.5-fold (0.19 log units) below, and the stated range covers the measured number.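

In this assay, the change on the core of compound 3 gives a 1.8-fold lower number from compound 3 to compound 4 (0.27 log units; within the scatter), so the measurement does not separate these two compounds. Set beside the step on the core of compound 1, the new step cannot be told apart from the earlier one: the same change on two cores in this assay, a 3.2-fold lower number (0.50 log units; beyond the scatter) from compound 2 to compound 1 and a 1.8-fold lower number (0.27 log units; within the scatter) from compound 3 to compound 4, 1.7-fold (0.23 log units) apart, within the scatter of two such steps. Going by these compounds alone, the two results are therefore compatible with a shared effect of similar size on both cores, but they do not establish one: only the step on the core of compound 1 lies beyond the scatter, the step on the core of compound 3 could be no real change, and each core is represented by a single pair in a single assay.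

Still open is whether a longer chain bearing the hydroxamic acid would extend the trend on either core or reverse it, since only two chain lengths are shown on each. Also open, going by these compounds, is how much the second hydroxamic acid contributes on the core of compound 3, a question that a carboxylic acid or a primary amide in its place could address while the rest of the structure stayed the same.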